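This account rests on a few compounds, and the source may have more. Where it says the series, first, only, none or still open, it means among the compounds named here.

The measured compounds:
compound 1, `Nc1nc(-c2ccc(Cl)cc2)c(CC(=O)O)s1`, > 100000 nM;
compound 2, `O=C(O)Cc1sc(COc2ccc(Cl)cc2)nc1-c1ccc(Cl)cc1`, 370 nM;
compound 3, `O=C(O)Cc1sc(C(c2ccc(F)cc2)c2ccc(F)cc2)nc1-c1ccco1`, 140 nM.

In an in vitro functional assay on HEK285-7 cells for antagonist activity at prostaglandin D2 receptor 2 (Homo sapiens), read by BRET and beta-arrestin recruitment (on this read-out higher numbers stand for weaker inhibition and lower numbers for stronger inhibition), compound 1 gives only a limit, > 100000 nM, and no number. Compound 2 gives 370 nM. Compound 3 gives 140 nM, the lowest of the two numbers shown, with compound 2 standing higher by a gap beyond the usual scatter.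

Compound 4, `Nc1cc(-c2nc(C(c3ccc(F)cc3)c3ccc(F)cc3)sc2CC(=O)O)cc(F)n1`, has not been measured. It differs from compound 3 in one place: 2-amino-6-fluoropyridin-4-yl in place of furan-2-yl on an aromatic carbon. The entering group brings a hydrogen-bond donor and a second acceptor where furan-2-yl offers a single acceptor. Among the compounds with values here, no measured pair shows a change of this kind, so the direction of the step cannot be read from the data; the two active compounds, compound 2 and compound 3, keep the carboxymethyl group and a large group on the shared core, and compound 4 keeps both as well. The step of a 1.4-fold lower number from compound 3 to compound 4 (0.15 log units; within the scatter) is therefore expected to stay within the scatter, or to lower the number slightly. The estimate for compound 4 in this assay is 100 nM, within a range from 30 nM to 400 nM.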

Compound 4, half-maximal inhibitory concentration: 1400 nM
Compound 4: middle estimate off by 14-fold (1.15 log units), on the low side, and the stated range ends below it.
By their numbers in this assay, from the lowest: compound 3; then compound 2; then compound 4. At a limit, above all of these: compound 1.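

The position on an aromatic carbon, next to the ring nitrogen and next to the ring atom that bears a carboxymethyl group, proves sensitive to what it carries: in this assay, 2-amino-6-fluoropyridin-4-yl in place of furan-2-yl gives a 10-fold higher number from compound 3 to compound 4 (1.00 log units; beyond the scatter). Within the data shown here, this is the first pair among the compounds that differs in one place, and it shows that keeping the carboxymethyl group and the large group on the shared core does not by itself hold the number at the level of compound 3. Nothing shown here gives a cause for this step.

From the compounds shown here alone, it remains open whether the step follows from the amine, the fluorine or the six-membered ring itself. An unsubstituted pyridin-4-yl, a 2-aminopyridin-4-yl and a 2-fluoropyridin-4-yl at this place would separate these three parts.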